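A few compounds are considered here, and "the series" means these few. Any claim that something is new, unique, unknown or untested is made for them only; others in the source may bear on it.

Of the compounds shown here, three share one core and have been tested in an assay on cells for displacement of a labelled ligand from adenosine receptor A1 (Homo sapiens), read by scintillation counting and radioligand binding, with a stated time of 60 min, tested at 10 uM; a higher number here means more inhibition at the concentration tested (going by the name of the read-out), a lower number less inhibition. Compound 1 `Cn1cnc2c(N3CCCCC3)nc(-c3cccc(O)c3O)nc21` gives 17.2%. Compound 2 `Clc1ccc(-c2nc(N3CCCCC3)c3nc[nH]c3n2)cc1` gives > 80%, which is a limit of the measurement rather than a number. Compound 3 `CN1CCN(c2nc(-c3ccc(Cl)cc3)nc3[nH]cnc23)CC1` gives > 80%, again a limit. The step that the two limits leave unreadable from compound 2 to compound 3 therefore cannot be sized; all that can be said is the limit of > 80% in this assay, at which 2 of the 3 values shown sit. Compound 2 thus stands at the top of what this assay can report, alongside compound 3, while compound 1 sits well below that limit.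

Compound 4 `Clc1cccc(-c2nc(N3CCCCC3)c3nc[nH]c3n2)c1` has not yet been measured in this assay. It differs from compound 2 in one place: 3-chlorophenyl in place of 4-chlorophenyl on an aromatic carbon. The chlorine simply moves to another position on the same aromatic ring; nothing else changes. Within the data shown here, none of the measured steps concerns this kind of change, so no measured size can be borrowed, and the only anchor is where compound 2 stands. Because compound 2 gives > 80%, compound 4 is expected to remain near that limit. For compound 4 the estimated value is 80%, with a range from 55% to 95%. The expected step is then a number no higher from compound 2 to compound 4 (the limit leaves the size open), within the scatter. The measured value will show whether this holds.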

Compound 4, a percentage reported as inhibition, at one concentration (the size of the read-out at that concentration, not a potency): > 80%
Compound 4 gave a limit, no number; the forecaster's own chance of this, stated with the estimate: 60%; the middle value lies on the limit itself.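

In this assay compound 4 gives > 80%, which is a limit and not a number. No step from compound 2 to compound 4 can be read, because both compounds sit at that limit: the limit of > 80% in this assay, at which 3 of the 4 values shown sit.

Going by these compounds, whether 3-chlorophenyl in place of 4-chlorophenyl changes the inhibition at all stays open.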